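The source may hold more compounds than are shown below. What is called first, only, known or untested is meant among the compounds shown, and "the series" means these compounds.

In a functional assay on HT-1080 cells (Homo sapiens) for cytotoxicity, read by MTT assay, with a stated time of 72 h (a higher number here means a weaker inhibitor, a lower number a stronger inhibitor), compound 1 (`COc1cccc(/C=C2\CCC/C(=C\c3cccc(Cl)c3Cl)C2=O)c1OC`) gives 19300 nM, while compound 2 (`COc1ccc(/C=C2\CCC/C(=C\c3ccccc3Br)C2=O)cc1OC`) gives 8400 nM. Compound 2 thus holds the lower of the two numbers, and its gap to compound 1 lies beyond the usual scatter. Compound 3 (`COc1ccc(/C=C2\CCC/C(=C\c3cccc(O)c3)C2=O)cc1OC`) has not yet been measured. It differs from compound 2 in one place, with 3-hydroxyphenyl in place of 2-bromophenyl on a double-bonded chain carbon bound to a double-bonded ring carbon. Neither measured compound carries the 3-hydroxyphenyl group, so the data offer no direct guide to this change. The starting point is therefore compound 2 at 8400 nM, and no step beyond the scatter is expected in this assay. The expected step is a 1.2-fold higher number from compound 2 to compound 3 (0.08 log units; within the scatter). For compound 3, the estimated value is 10000 nM, within an expected range of 3000 nM to 30000 nM.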

Compound 3, half-maximal inhibitory concentration: 1700 nM
Beside the measured number, compound 3's estimate is 5.9-fold (0.77 log units) above it; measured number below the stated range.
By their numbers in this assay, from the lowest: compound 3; then compound 2; then compound 1.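

In this assay, the group on a double-bonded chain carbon bound to a double-bonded ring carbon proves able to shift the number: 3-hydroxyphenyl in place of 2-bromophenyl gives a 4.9-fold lower number from compound 2 to compound 3 (0.69 log units; beyond the scatter). The two groups have the same count of heavy atoms, yet the entering group carries a hydrogen-bond donor and a hydrogen-bond acceptor, and the leaving group carries neither. Nothing available explains why the number falls with this change.

The single change swaps both the substituent and its place on the phenyl ring, so the compounds shown cannot separate the contribution of each. Going by these compounds, whether 3-bromophenyl or 2-hydroxyphenyl would follow compound 3 or compound 2, and whether 3-methoxyphenyl or 3-aminophenyl would keep the lower number, remains open.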